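Uncoupler-type series: pentafluorosulfanyl anilino analogue and an acetyl replacement

The source may hold more compounds than are shown below. What is called first, only, known or untested is meant among the compounds shown, and "the series" means these compounds.

Measured so far:
compound 1, `Oc1nc2nonc2nc1Nc1ccc(S(F)(F)(F)(F)F)cc1` — 3900 nM
compound 2, `Cc1ccc(C(F)(F)F)cc1Nc1nc2nonc2nc1O` — 32800 nM

The read-out is an assay on mitochondria from L6 cells (Rattus norvegicus) for activation, with a stated time of 90 min; a lower number here means that less compound is needed, a higher number that more compound is needed for the effect. Compound 1 gives the lowest of the two numbers in this assay, and the step to compound 2 is beyond the usual scatter, so compound 1 clearly needs less compound than compound 2 for the same effect. Within the data shown here, no pair of measured compounds differs in one place only, so no single-point step is available as a reference.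

Compound 3, `CC(=O)c1ccc(Nc2nc3nonc3nc2O)cc1`, is not yet measured. Relative to compound 1 the change is a group of 3 heavy atoms (2 carbon, 1 oxygen; no ring) in place of a group of 6 heavy atoms (5 fluorine, 1 sulfur; no ring), on an aromatic carbon, on an aromatic carbon of the six-membered carbon-only ring, para to a large group.

With nothing in the measured pairs to anchor this exchange, the expectation for compound 3 is a moderate rise in this assay: the step of a 3.1-fold higher number from compound 1 to compound 3 (0.49 log units; beyond the scatter) is estimated to go upward, beyond the scatter but not dramatically. Compound 3 is therefore expected at about 12000 nM, with a range from 3000 nM to 45000 nM.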

Compound 3, half-maximal effective concentration: 93700 nM
Compound 3: the middle estimate sits 7.8-fold (0.89 log units) below what was measured; the measured number lies above the stated range.
By their numbers in this assay, from the lowest: compound 1; then compound 2; then compound 3.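

In this assay, among these compounds, replacing the pentafluorosulfanyl group with acetyl on the aromatic carbon para to a large group gives a 24-fold higher number from compound 1 to compound 3 (1.38 log units; beyond the scatter) and provides the first single-place comparison. With the rest of compound 1 unchanged, the group at this position alone can therefore shift the number substantially, and this exchange moves it in the unfavourable direction. No measurement available here bears on the origin of this step.

The compounds shown leave open whether other groups at this position, such as a nitrile, an amine or a carboxylic acid, would stay close to compound 1 or move towards compound 3, since a single exchange defines only two points and no trend. On these data alone, compound 2 differs from compound 1 in more than one place, so the separate contributions of its changes cannot be read, and the shared core remains untested against any change outside this aromatic ring.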